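The compounds below may be only part of what the source reports. "The series", "measured", "known", "first", "only" and "open" are said of these compounds alone.

Compound 2 `O=C(NC(=S)NNc1ncnc2ccccc12)c1ccc(F)cc1`: 6070 nM
Compound 1 `COc1cc2ncnc(NNC(=S)NC(=O)c3ccc(F)cc3)c2cc1OC`: 15300 nM

In a functional assay on GLC82 cells (Homo sapiens) for cytotoxicity, read by MTT assay, with a stated time of 72 h (on this read-out lower numbers stand for stronger inhibition and higher numbers for weaker inhibition), compound 2 gives 6070 nM, the lowest of the two numbers. Compound 1 gives 15300 nM, a gap that lies beyond the scatter. Compound 3 `O=C(NC(=S)NNc1ncnc2ccccc12)c1cccc(Cl)c1` has not been measured. It differs from compound 2 in one place: 3-chlorophenyl in place of 4-fluorophenyl on a carbonyl carbon. Among the measured compounds shown here, no measured pair shows how this exchange acts, so the account rests on compound 2 alone, and a shift of only modest size is expected, for compound 3 the step of a 1.2-fold lower number from compound 2 to compound 3 (0.08 log units; within the scatter), not clearly beyond the scatter. Compound 3 is estimated at 5000 nM, within a range from 2000 nM to 15000 nM.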

Compound 3, half-maximal inhibitory concentration: 3240 nM
For compound 3 the middle estimate is 1.5-fold (0.19 log units) above the measured one, within the range that was stated.
By their numbers in this assay, from the lowest: compounds 3 and 2 (each within the scatter of the next); then compound 1.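

In this assay, 3-chlorophenyl in place of 4-fluorophenyl on a carbonyl carbon gives a 1.9-fold lower number from compound 2 to compound 3 (0.27 log units; within the scatter), the first step seen at this position. This exchange of one halogen-bearing phenyl group for another therefore leaves the cytotoxicity read-out of compound 3 level with that of compound 2. Nothing measured here accounts for the step.

Open, as far as these compounds go, is how this position responds to a group of another kind, such as an amine, a carboxylic acid or a longer alkyl chain in place of the phenyl ring.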